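Adding a second hydroxy group to an inactive compound

The source may hold more compounds than are shown below. What is called first, only, known or untested is meant among the compounds shown, and "the series" means these compounds.

In a functional assay on brain (Rattus norvegicus, strain Wistar) for inhibition (a higher number here means a weaker inhibitor, a lower number a stronger inhibitor), compound 1 (`COc1ccc2c(c1)OC/C(=C\c1ccc(O)cc1)C2=O`) gives > 100000 nM as a limit of the assay. Compound 2 (`COc1ccc(/C=C2\COc3cc(OC)ccc3C2=O)cc1`) gives > 100000 nM as a limit too. The evidence so far is the limit of > 100000 nM in this assay, at which 2 of the 2 values shown sit, and nothing more. Going by the values given here, the one measured step is a step that the two limits leave unreadable from compound 1 to compound 2 and offers no size to carry over. Compound 3 (`COc1ccc2c(c1)OC/C(=C\c1ccc(O)c(O)c1)C2=O`) follows from compound 1 through hydroxy in place of hydrogen on an aromatic carbon with the new hydroxy ortho to a hydroxy group. A modest move toward stronger inhibition is expected as an at least 3.3-fold lower number from compound 1 to compound 3 (0.52 log units; beyond the scatter) in this assay and a reading at the limit remains quite possible. Compound 3 is estimated at 30000 nM with 3000 nM to 100000 nM as the expected range.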

Compound 3, half-maximal inhibitory concentration: 12100 nM
The estimate for compound 3 lay 2.5-fold (0.39 log units) above the measured number, and the stated range covers the measured number.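

On this position of the aromatic ring, ortho to a hydroxy group, hydroxy in place of hydrogen gives an at least 8.2-fold lower number from compound 1 to compound 3 (0.91 log units; beyond the scatter) in this assay. The size is only a bound, as the value for compound 1 is a limit. Compound 3 is the one compound shown with a number rather than a limit: the limit of > 100000 nM in this assay, at which 2 of the 3 values shown sit.

The step between the two limits cannot be read. Open, from the compounds shown here alone, is whether an amine or a carboxylic acid on the same carbon would serve as well, and whether the new hydroxy acts without the existing hydroxy group.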